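The source may hold more compounds than are shown below. What is called first, only, known or untested is meant among the compounds shown, and "the series" means these compounds.

Three compounds share one core and were tested in a functional assay on MKN-45 cells (Homo sapiens) for cytotoxicity, read by MTT assay, with a stated time of 72 h; on this read-out lower numbers stand for stronger inhibition and higher numbers for weaker inhibition. Compound 1 `CN(C)CCCNc1nc(-c2ccc(NC(=O)Nc3ccc(Cl)cc3)cc2)nc2c(Cl)c(Cl)sc12` gives 1530 nM. Compound 3 `CN(C)CCNc1nc(-c2ccc(NC(=O)Nc3ccccc3)cc2)nc2ccsc12` gives 1120 nM, and compound 2 `CN(C)CCCNc1nc(-c2ccc(NC(=O)Nc3ccc(Cl)cc3Cl)cc2)nc2ccsc12` gives 2270 nM. Compound 1 thus stands second highest of the three numbers, but its gaps to compound 3 and to compound 2 both lie within the usual scatter of repeated measurements, so the three compounds are not separated from one another.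

Compound 4 `CN(C)CCCNc1nc(-c2ccc(NC(=O)Nc3ccc(Cl)cc3Cl)cc2)nc2c(Cl)c(Cl)sc12` has not yet been measured. It differs from compound 1 in one place: chloro in place of hydrogen on an aromatic carbon. Going by the values given here, no measured pair differs by exactly this change, so the size of the step cannot be read from the data. Compound 2 carries the same 2,4-dichlorophenyl group on a different core and gives a number close to that of compound 1, so no step beyond the scatter is expected. Compound 4 is therefore expected to differ by a 1.2-fold higher number from compound 1 to compound 4 (0.09 log units; within the scatter). Compound 4 is estimated at 1900 nM, with a range from 900 nM to 4000 nM.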

Compound 4, half-maximal inhibitory concentration: 2560 nM
For compound 4 the middle estimate is 1.3-fold (0.13 log units) below the measured one; low and high end bracket the measured number.
By their numbers in this assay, from the lowest: compounds 3, 1, 2 and 4 (each within the scatter of the next, the first and the last beyond it).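

In this assay, the change from 4-chlorophenyl to 2,4-dichlorophenyl places a chloro on an aromatic carbon, ortho to a large group and meta to the existing chloro group, and gives a 1.7-fold higher number from compound 1 to compound 4 (0.22 log units; within the scatter). This is the first pair shown that differs in only one place, so the effect of this change can now be read directly, and on this core it stays within the usual scatter of repeated measurements. No supporting data bear on the size of this step.

The compounds shown leave open whether a methoxy group or an amine in place of this chloro would give a step beyond the scatter. Also open, from the compounds shown here alone, is whether the same chloro-for-hydrogen change would give a step of similar size on the core of compound 2.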